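This account rests on a few compounds, and the source may have more. Where it says the series, first, only, none or still open, it means among the compounds named here.

Working notes on the series.

Compound 1, `c1cncc(-c2ccccc2OCC2=NCCN2)c1`, is the reference for this step. In a functional assay for activation of Alpha-1A adrenergic receptor (Homo sapiens), read by calcium flux (a lower number here means that less compound is needed, a higher number that more compound is needed for the effect), compound 1 gives 2 nM, the lower of the two numbers in hand, though its nearest neighbour lies within the scatter. Compound 3, `c1ccc(-c2cnccn2)c(OCC2=NCCN2)c1`, gives 2.51 nM in this assay, and the step of a 1.3-fold higher number from compound 1 to compound 3 (0.10 log units; within the scatter) counts as no change. Compound 2, `c1ccc(-c2ccncc2)c(OCC2=NCCN2)c1`, gives only a limit in this assay, < 100000 nM, and not a number. For that reason the step that the limit leaves unreadable from compound 1 to compound 2 cannot be sized, and the same holds for a step that the limit leaves unreadable from compound 2 to compound 3; what lies behind this is the limit of < 100000 nM in this assay, at which 1 of the 3 values shown sits.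

Compound 4, `c1ccc(-c2ccoc2)c(OCC2=NCCN2)c1`, is not yet measured. It differs from compound 1 as follows: furan-3-yl in place of pyridin-3-yl on an aromatic carbon. Within the data shown here, the only readable step at this place, a 1.3-fold higher number from compound 1 to compound 3 (0.10 log units; within the scatter), exchanged one six-membered ring with one hetero atom for another and moved the number by nothing beyond the scatter. Among the measured compounds shown here, a five-membered ring with an oxygen has no direct precedent here, so the expectation leans on compound 1 at 2 nM and allows for more spread. The step from compound 1 to compound 4 is expected to be a 2.5-fold higher number from compound 1 to compound 4 (0.40 log units; beyond the scatter). Compound 4 is therefore estimated at 5 nM, with a range from 1 nM to 40 nM.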

Compound 4, half-maximal effective concentration: 0.501 nM
Compound 4: the middle estimate sits 10-fold (1.00 log units) above what was measured; measured number outside the range, below it.
By their numbers in this assay, from the lowest: compound 4; then compounds 1 and 3 (each within the scatter of the next).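

Furan-3-yl on an aromatic carbon of a six-membered aromatic ring of carbon only gives the first readable change at this place that lies beyond the scatter: a 4.0-fold lower number from compound 1 to compound 4 (0.60 log units; beyond the scatter) and a 5.0-fold lower number from compound 3 to compound 4 (0.70 log units; beyond the scatter), both in this assay. The place therefore accepts a five-membered aromatic ring with an oxygen as well as the six-membered aromatic rings of compound 1 and compound 3, and the number goes down, although the hydrogen-bond donor and acceptor counts under this change stay the same as for pyridin-3-yl. The step from compound 2 to compound 4 cannot be read, and compound 2 remains a limit and not a number: the limit of < 100000 nM in this assay, at which 1 of the 4 values shown sits.

The compounds shown change ring size and hetero atom together, so they cannot say which of the two goes with the lower number; thiophen-3-yl, pyrrol-3-yl, furan-2-yl or plain phenyl at this place would bear on that. Also open, going by these compounds, is how far the step holds outside aromatic rings, for example with an aminomethyl group, a carboxylic acid or a longer alkyl chain at the same place.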